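Series notes: methylamino to ethylamino step

The source may hold more compounds than are shown below. What is called first, only, known or untested is meant among the compounds shown, and "the series" means these compounds.

Measured so far in a functional assay on A2780 cells (Homo sapiens) for antiproliferative activity, read by MTT assay, with a stated time of 48 h; on this read-out lower numbers stand for stronger inhibition and higher numbers for weaker inhibition:
compound 1 `CNCC(=O)Nc1cc(OC)ccc1C(=O)c1ccc(OC)c2c1C=CC(C)(C)O2` gives 1590 nM
compound 2 `CNCC(=O)Nc1cc(OC)ccc1C(=O)c1ccc2c(c1)C=CC(C)(C)O2` gives 850 nM
compound 3 `CCNCC(=O)Nc1cc(OC)ccc1C(=O)c1ccc(OC)c2c1C=CC(C)(C)O2` gives 4090 nM

Compound 3 differs from compound 1 by methyl in place of hydrogen on a saturated chain carbon bound to an amine nitrogen. In this assay this change gave a 2.6-fold higher number from compound 1 to compound 3 (0.41 log units; beyond the scatter). Compound 2 has the lowest number of the three, but its gap to compound 1 lies within the scatter, so no order between those two is claimed; its gap to compound 3 lies beyond the scatter. The difference between the core of compound 1 and the core of compound 2 is not broken down here.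

Compound 4 `CCNCC(=O)Nc1cc(OC)ccc1C(=O)c1ccc2c(c1)C=CC(C)(C)O2` has not yet been measured. Among the compounds with values here, it differs from compound 2 by methyl in place of hydrogen on a saturated chain carbon bound to an amine nitrogen, the same change at the same place as the one from compound 1 to compound 3. Within the data shown here, only that single earlier example is available, so the expectation in this assay rests on it alone: a step of about a 2.6-fold higher number from compound 2 to compound 4 (0.41 log units; beyond the scatter) is expected because the same change gave a 2.6-fold higher number from compound 1 to compound 3 (0.41 log units; beyond the scatter). Compound 4 is accordingly estimated at 2200 nM, with a likely range from 1000 nM to 4800 nM.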

Compound 4, half-maximal inhibitory concentration: 2070 nM
Beside the measured number, compound 4's estimate is 1.1-fold (0.03 log units) above it, and the stated range covers the measured number.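

Working note on the methylamino to ethylamino change: in this assay, the change on the core of compound 2 gave a 2.4-fold higher number from compound 2 to compound 4 (0.39 log units; beyond the scatter). The step carried over from one core to the other with its size and direction kept: the same change on two cores in this assay, a 2.6-fold higher number (0.41 log units; beyond the scatter) from compound 1 to compound 3 and a 2.4-fold higher number (0.39 log units; beyond the scatter) from compound 2 to compound 4, 1.1-fold (0.02 log units) apart, within the scatter of two such steps. This shows that, on these two cores, the change behaves alike and the difference between the cores leaves the step unaltered within the scatter, but two pairs in a single cell assay do not establish a general rule for the series, and they say nothing about why the number rises or how the change would behave on any further core.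

Still open, from the compounds shown here alone, is whether the rise continues with a longer chain such as propylamino, and where a primary amine or a dimethylamino group would fall on either core. Also open, going by these compounds, is whether the step keeps its size on a core bearing a different substituent, such as a hydroxyl or a fluorine.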